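The source may report more compounds than this note shows. Statements on the series, on what has been measured and on what is new or still open speak of the compounds shown alone.

Compound 3 `O=C(c1ccccc1Cl)N1N=C(c2cc3ccccc3oc2=O)CC1c1ccccc1` is one of three compounds sharing a core in which a five-membered non-aromatic ring with two nitrogens carries a phenyl group and an acyl group on a ring nitrogen. In a functional assay on MGC-803 cells (Homo sapiens) for cytotoxicity, read by MTT assay, with a stated time of 48 h (a higher number here means a weaker inhibitor, a lower number a stronger inhibitor), compound 3 gives 6640 nM. Compound 1 `Cc1ccc(C(=O)N2N=C(c3cc4ccccc4oc3=O)CC2c2ccccc2)cc1` gives 31300 nM in this assay, and compound 2 `CCC(=O)N1N=C(c2cc3ccccc3oc2=O)CC1c1ccccc1` gives 5300 nM. Compound 3 thus sits between the other two: the step of a 4.7-fold lower number from compound 1 to compound 3 (0.67 log units; beyond the scatter) is a modest gain, whereas the step of a 1.3-fold higher number from compound 2 to compound 3 (0.10 log units; within the scatter) lies within the scatter, so compound 2 and compound 3 cannot be told apart on these numbers.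

Compound 4 `Cc1ccc(S(=O)(=O)N2N=C(c3cc4ccccc4oc3=O)CC2c2ccccc2)cc1` is not yet measured. It differs from compound 3 by (4-methylphenyl)sulfonyl in place of (2-chlorophenyl)carbonyl on an amine nitrogen in a ring. The step of a 4.7-fold lower number from compound 1 to compound 3 (0.67 log units; beyond the scatter) bears on it. Compound 1 carries the same 4-methylphenyl ring that returns in compound 4, and that ring on a carbonyl carbon went with the highest number of the three. The step of a 5.9-fold lower number from compound 1 to compound 2 (0.77 log units; beyond the scatter) shows the same direction. Going by the values given here, no measured compound holds a sulfonyl group, so the effect of replacing the carbonyl by a sulfonyl is unknown from these data. A modest step upward is therefore expected, a 1.8-fold higher number from compound 3 to compound 4 (0.26 log units; within the scatter), toward the number of compound 1. Compound 4 is estimated at 12000 nM, within a range from 4000 nM to 40000 nM.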

Compound 4, half-maximal inhibitory concentration: 50200 nM
Compound 4: middle estimate off by 4.2-fold (0.62 log units), on the low side; measured number above the stated range.
By their numbers in this assay, from the lowest: compounds 2 and 3 (each within the scatter of the next); then compounds 1 and 4 (each within the scatter of the next).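

In this assay, going by these compounds alone, this position on the amine nitrogen in the ring carries a sulfonyl group for the first time, and with the 4-methylphenyl ring kept, the exchange of carbonyl for sulfonyl gives a step that cannot be resolved (a 1.6-fold higher number from compound 1 to compound 4 (0.21 log units; within the scatter)). The sulfonyl compound instead separates from the two compounds without a 4-methylphenyl ring (a 7.6-fold higher number from compound 3 to compound 4 (0.88 log units; beyond the scatter); a 9.5-fold higher number from compound 2 to compound 4 (0.98 log units; beyond the scatter)), so among these four compounds the numbers fall into two groups that follow the 4-methylphenyl ring, whether it sits on a carbonyl or a sulfonyl, and no compound shown goes against this. Nothing available here explains this grouping.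

From the compounds shown here alone, whether a sulfonyl group bearing ethyl or 2-chlorophenyl would group with compound 4 or with compound 2 and compound 3 remains open, so the contribution of the sulfonyl group cannot be separated from that of the ring it carries in any other setting. Also open, going by these compounds, is how this position would respond to an unsubstituted benzoyl group, a longer acyl chain, or an acyl group ending in an amine or a carboxylic acid.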